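Chloro in place of hydrogen on two related cores

The source may hold more compounds than are shown below. What is called first, only, known or untested is meant among the compounds shown, and "the series" means these compounds.

Measured in a functional assay on NCI-H522 cells (Homo sapiens) for cytotoxicity, read by sulforhodamine B assay, with a stated time of 48 h; a lower number here means a stronger inhibitor of growth, a higher number a weaker inhibitor of growth:
compound 1 `ClCc1ccccc1Cn1cnc2c(Cl)nc(Cl)nc21` gives 1990 nM
compound 2 `ClCc1ccccc1Cn1cnc2c(Cl)ncnc21` gives 7240 nM
compound 3 `ClCc1ccccc1Cn1cnc2ncnc(Cl)c21` gives 75900 nM

Compound 1 and compound 2 share a core. Compound 1 carries the change (chloro in place of hydrogen on an aromatic carbon), and the step in this assay is a 3.6-fold lower number from compound 2 to compound 1 (0.56 log units; beyond the scatter). Compound 3 is built from the same atoms as compound 2, joined differently; the difference between the two cores is not broken down here. In this assay compound 3 stands highest of the three numbers, well above compound 2 and further still above compound 1, both gaps beyond the scatter.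

Compound 4 `ClCc1ccccc1Cn1cnc2nc(Cl)nc(Cl)c21` has not been measured. It differs from compound 3 by chloro in place of hydrogen on an aromatic carbon, the same change that separates compound 2 from compound 1, at the same place on the ring. Since the step of a 3.6-fold lower number from compound 2 to compound 1 (0.56 log units; beyond the scatter) lowered the number beyond the scatter on the first core, compound 4 is expected to sit below compound 3 by a comparable step, a 3.5-fold lower number from compound 3 to compound 4 (0.54 log units; beyond the scatter). This expectation rests on a single precedent on a different core, so the range is kept broad. Compound 4 is estimated at 22000 nM, between 8000 nM and 60000 nM.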

Compound 4, concentration for total growth inhibition: 7240 nM
Compound 4: middle estimate off by 3.0-fold (0.48 log units), on the high side; the measured number lies below the stated range.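

In this assay, chloro in place of hydrogen on an aromatic carbon lowers the number on both cores, and the step on the core of compound 3 is the larger one (a 10-fold lower number from compound 3 to compound 4 (1.02 log units; beyond the scatter)). The direction of the change carries from one core to the other, but its size does not: the same change on two cores in this assay, a 3.6-fold lower number (0.56 log units; beyond the scatter) from compound 2 to compound 1 and a 10-fold lower number (1.02 log units; beyond the scatter) from compound 3 to compound 4, 2.9-fold (0.46 log units) apart, beyond the scatter of two such steps. This shows that a step measured on one core gave the sign on the other but not a reliable magnitude; it does not show why the two steps differ, and two pairs of compounds give no rule for how large the step would be on any further core.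

The compounds shown leave open whether the gap between the cores is specific to chloro, since no other group, such as an amine or a methoxy group, appears in that place on either core. Also open is whether the two steps would keep their difference with a methyl or hydroxymethyl group in place of the chloromethyl group, which stays unchanged across all the compounds shown.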